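The source may hold more compounds than are shown below. What is called first, only, known or untested is meant among the compounds shown, and "the series" means these compounds.

Compound 1 `CCOC(=O)c1cnn(-c2nc(-c3ccccc3Cl)c(C#N)c(=O)n2C)c1N`: 98 ug/mL
Compound 2 `CCOC(=O)c1cnn(-c2nc(-c3ccc(Cl)cc3)c(C#N)c(=O)n2C)c1N`: 94 ug/mL
Compound 3 `Cn1c(NN)nc(-c2ccc(Cl)cc2)c(C#N)c1=O`: 41 ug/mL

In a functional assay, with a stated time of 10 min (a lower number here means a stronger inhibitor, a higher number a weaker inhibitor), compound 2 gives 94 ug/mL. Compound 1 gives 98 ug/mL, a number that sits with that of compound 2 within the scatter, and compound 3 gives 41 ug/mL, a lower number that lies beyond the scatter from compound 2. The unmeasured compound 4 `CCOC(=O)c1cnn(-c2nc(-c3ccc(OC)cc3)c(C#N)c(=O)n2C)c1N` differs from compound 2 by one change: methoxy in place of chloro on an aromatic carbon. Within the data shown here, the only measured step that touches the same six-membered ring is a 1.0-fold lower number from compound 1 to compound 2 (0.02 log units; within the scatter), and it concerned the place of the chloro group, not its exchange for another group. Among the measured compounds shown here, no measured pair exchanges a chloro for a methoxy, so that step gives no direct guide; it shows only that a change on this ring left the number nearly unmoved. Compound 4 is therefore expected to give about 100 ug/mL, within 45 ug/mL to 220 ug/mL. The expected step of a 1.1-fold higher number from compound 2 to compound 4 (0.03 log units; within the scatter) is estimated to stay within the scatter.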

Compound 4, half-maximal inhibitory concentration: 74 ug/mL
For compound 4 the middle estimate is 1.4-fold (0.13 log units) above the measured one; the measured number falls inside the stated range.
By their numbers in this assay, from the lowest: compounds 3, 4, 2 and 1 (each within the scatter of the next, the first and the last beyond it).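

In this assay the group itself is now exchanged at this place, on an aromatic carbon para to a large group, and not merely shifted around the ring: a 1.3-fold lower number from compound 2 to compound 4 (0.10 log units; within the scatter) is a step that stays within the scatter. Taken with a 1.3-fold lower number from compound 1 to compound 4 (0.12 log units; within the scatter), this shows that 2-chlorophenyl, 4-chlorophenyl and 4-methoxyphenyl are not told apart by this assay, even though methoxy brings a hydrogen-bond acceptor that chloro lacks. Nothing at hand accounts for this flat result.

As far as these compounds go, whether this tolerance extends beyond these three groups remains open. An amine or a carboxylic acid at the same place, or a longer chain in place of the methoxy, might still move the number beyond the scatter.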